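Replacing an Aryl Ether with a Phenylsulfonyl Group

The compounds below may be only part of what the source reports. "The series", "measured", "known", "first", "only" and "open" are said of these compounds alone.

In a functional assay for inhibition, with Homo sapiens as the target (on this read-out higher numbers stand for weaker binding and lower numbers for tighter binding), compound 1 `CC(C)(Oc1ccccc1)C1OCC(C/C=C\CCC(=O)O)C(c2cccnc2)O1` gives 75.9 nM, compound 2 `CC(C)(Oc1ccccc1F)C1OCC(C/C=C\CCC(=O)O)C(c2cccnc2)O1` gives 166 nM and compound 3 `COc1ccccc1OC(C)(C)C1OCC(C/C=C\CCC(=O)O)C(c2cccnc2)O1` gives 224 nM. Compound 3 therefore belongs to the upper pair of numbers, with a 1.3-fold higher number from compound 2 to compound 3 (0.13 log units; within the scatter). Compound 4 `CC(C)(C1OCC(C/C=C\CCC(=O)O)C(c2cccnc2)O1)S(=O)(=O)c1ccccc1` carries phenylsulfonyl in place of 2-methoxyphenoxy on a saturated chain carbon bound to two saturated chain carbons and a saturated ring carbon. Two modest steps bear on this, a 2.2-fold higher number from compound 1 to compound 2 (0.34 log units; beyond the scatter) and a 3.0-fold higher number from compound 1 to compound 3 (0.47 log units; beyond the scatter), each adding a group to the aromatic ring that compound 4 lacks. Within the data shown here, no measured step tests the sulfonyl group itself, so the uncertainty is wide. In this assay, a small 1.5-fold lower number from compound 3 to compound 4 (0.17 log units; within the scatter) is expected, not beyond the scatter. The estimate for compound 4 is 150 nM, with an expected range of 40 nM to 600 nM.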

Compound 4, dissociation constant: 3160 nM
Estimate against measurement, compound 4: 21-fold (1.32 log units) below; measured number outside the range, above it.
By their numbers in this assay, from the lowest: compound 1; then compounds 2 and 3 (each within the scatter of the next); then compound 4.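

At this saturated chain carbon, phenylsulfonyl matches each ether group in heavy atoms and hydrogen-bond acceptors and also brings an aromatic ring, yet the change gives a 14-fold higher number from compound 3 to compound 4 (1.15 log units; beyond the scatter) and a 19-fold higher number from compound 2 to compound 4 (1.28 log units; beyond the scatter) and a 42-fold higher number from compound 1 to compound 4 (1.62 log units; beyond the scatter) in this assay alike. Changing the whole group here therefore moves the number far more than the modest steps from adding fluoro or methoxy to the aromatic ring. No evidence at hand gives a reason for this rise. Still open, on these data alone, is whether a phenylthio or benzyl group at this carbon would keep the low numbers of the ethers or follow phenylsulfonyl.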